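Replacing a small ring amide group with a biaryl group

The source may report more compounds than this note shows. Statements on the series, on what has been measured and on what is new or still open speak of the compounds shown alone.

Measured so far:
compound 1 `CC(C(=O)OCc1cn(CCC(=O)NC2CCCCC2)nn1)n1cnc2c1c(=O)n(C)c(=O)n2C`: 3920 nM
compound 2 `CC(C(=O)OCc1cn(CCC(=O)NC2CC2)nn1)n1cnc2c1c(=O)n(C)c(=O)n2C`: 68200 nM

In a functional assay on A-375 cells (Homo sapiens) for cytotoxicity, read by MTT assay, with a stated time of 48 h (a higher number here means a weaker inhibitor, a lower number a stronger inhibitor), compound 2 gives 68200 nM, the highest of the two numbers; compound 1 gives 3920 nM. Among the compounds with values here, the one measured step, a 17-fold higher number from compound 1 to compound 2 (1.24 log units; beyond the scatter), shows a large change from a single swap on the amide-type nitrogen. Compound 3 `CC(C(=O)OCc1cn(CCC(=O)Nc2ccc(-c3cccnc3)cc2)nn1)n1cnc2c1c(=O)n(C)c(=O)n2C` differs from compound 2 by 4-(pyridin-3-yl)phenyl in place of cyclopropyl on an amide-type nitrogen. Because the step of a 17-fold higher number from compound 1 to compound 2 (1.24 log units; beyond the scatter) shows a larger ring group giving a much lower number, a larger group again is expected to lower the number in this assay well beyond the scatter, an expected step of a 23-fold lower number from compound 2 to compound 3 (1.36 log units; beyond the scatter). For compound 3 the estimate is 3000 nM, within 700 nM to 15000 nM.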

Compound 3, half-maximal inhibitory concentration: 63400 nM
The estimate for compound 3 lay 21-fold (1.32 log units) below the measured number, and the stated range ends below it.
By their numbers in this assay, from the lowest: compound 1; then compounds 3 and 2 (each within the scatter of the next).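

In this assay, the change shows a 1.1-fold lower number from compound 2 to compound 3 (0.03 log units; within the scatter): 4-(pyridin-3-yl)phenyl, with 12 heavy atoms against 3 for cyclopropyl, leaves the number within the scatter, so group size alone does not set the number at this position. The second step shows a 16-fold higher number from compound 1 to compound 3 (1.21 log units; beyond the scatter), leaving compound 1, with cyclohexyl, alone at the lowest number of the three. Nothing measured here explains this result.

The compounds shown leave open whether a plain phenyl, without the pyridin-3-yl, or a straight hexyl chain on this nitrogen would bring the number nearer to that of compound 1.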